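This account rests on a few compounds, and the source may have more. Where it says the series, first, only, none or still open, it means among the compounds named here.

Measured compounds:
compound 1, `ClCc1ccccc1Cn1cnc2c(Cl)nc(Cl)nc21`: 3230 nM
compound 2, `ClCc1cccc(Cn2cnc3c(Cl)ncnc32)c1`: 33900 nM
compound 3, `ClCc1ccc(Cn2cnc3nc(Cl)nc(Cl)c32)cc1`: 3460 nM

In a functional assay on EKVX cells (Homo sapiens) for cytotoxicity, read by sulforhodamine B assay, with a stated time of 48 h (on this read-out lower numbers stand for stronger inhibition of growth and higher numbers for weaker inhibition of growth), compound 2 gives 33900 nM, the highest of the three numbers; compound 3 gives 3460 nM and compound 1 gives 3230 nM, both lower by a margin beyond the scatter. Compound 4, `ClCc1cccc(Cn2cnc3c(Cl)nc(Cl)nc32)c1`, differs from compound 2 by chloro in place of hydrogen on an aromatic carbon. With that change compound 4 carries the same core as compound 1 and compound 3. Among the measured compounds shown here, no measured pair shows this exact change. The step from compound 2 to compound 4 is nonetheless expected to be a drop beyond the scatter, a 7.5-fold lower number from compound 2 to compound 4 (0.88 log units; beyond the scatter), because compound 1 at 3230 nM and compound 3 at 3460 nM show where that core has landed. Compound 4 is expected to give about 4500 nM in this assay, within a range from 1500 nM to 13000 nM.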

Compound 4, concentration for total growth inhibition: 2310 nM
Compound 4: the middle estimate sits 1.9-fold (0.29 log units) above what was measured; the range from low to high includes it.
By their numbers in this assay, from the lowest: compounds 4, 1 and 3 (each within the scatter of the next); then compound 2.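

In this assay, among the compounds shown here, chloro in place of hydrogen on the aromatic carbon between two ring nitrogen atoms brings a 15-fold lower number from compound 2 to compound 4 (1.17 log units; beyond the scatter) and gives the first direct reading of this position. The step is large, so this position responds strongly to a single chlorine atom, at least with this chloromethyl-substituted benzyl group in place. From the compounds shown here alone, whether an amine, a methoxy group or a methyl group at this position would keep that gain remains open. No measurement shown explains the size of this step.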